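The compounds below may be only part of what the source reports. "The series", "measured", "known", "first", "only" and "open" are said of these compounds alone.

Measured compounds:
- compound 1 `Cc1cccnc1-c1ccccc1OCC1=NCCN1`, which in a functional assay for activation of Alpha-1D adrenergic receptor (Homo sapiens), read by calcium flux (on this read-out lower numbers stand for an effect already at smaller amounts and higher numbers for an effect only at larger amounts of compound), gives only a limit of < 100000 nM
- compound 2 `c1csc(-c2ccccc2OCC2=NCCN2)c1`, which in this assay gives 15.9 nM

Of the compounds shown here, two have been measured so far, and only one of them yields a number. Compound 1 reaches just a limit in this assay, so its value is an assay boundary rather than a measurement, as the evidence the limit of < 100000 nM in this assay, at which 1 of the 2 values shown sits, makes clear. Among the compounds with values here, compound 2, with its thiophen-2-yl group on the aromatic carbon of the six-membered carbon ring, therefore stands as the only compound with a genuine value in this assay, and nothing can be said about any step between measured compounds.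

The next compound, compound 3 `c1ccc(-c2nccs2)c(OCC2=NCCN2)c1`, differs from compound 2 in a single place: 1,3-thiazol-2-yl in place of thiophen-2-yl on an aromatic carbon. The five-membered ring keeps its size and its sulfur, but a ring carbon is exchanged for a nitrogen, so the group carries one more hydrogen-bond acceptor.

Within the data shown here, with no measured step to lean on, the expectation is a modest loss rather than a large one. The step from compound 2 to compound 3 in this assay is expected to be a 2.5-fold higher number from compound 2 to compound 3 (0.40 log units; beyond the scatter), a change close to the usual scatter. Compound 3 is thus estimated at 40 nM, within a range from 8 nM to 250 nM.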

Compound 3, half-maximal effective concentration: 31.6 nM
Compound 3: the middle estimate sits 1.3-fold (0.10 log units) above what was measured, within the range that was stated.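

Within the data shown here, this is the first step that can be read: in this assay, putting 1,3-thiazol-2-yl in place of thiophen-2-yl on an aromatic carbon of the six-membered ring gives a 2.0-fold higher number from compound 2 to compound 3 (0.30 log units; within the scatter). At this place, then, a five-membered ring with 2 hetero atoms serves as well as one with 1 hetero atom, and the extra hydrogen-bond acceptor leaves the two compounds indistinguishable on this read-out. What the measured data cannot supply is a reason why the exchange leaves the read-out within the scatter, as nothing shown bears on this step.

Among these compounds, compound 1 remains a limit of < 100000 nM rather than a number, so no step that involves it can be read. Still open, from the compounds shown here alone, is how far this freedom at the same place extends, for example to a furan-2-yl ring, which has oxygen in place of sulfur, to a plain phenyl ring, or to a group of a different kind such as an amine or a carboxylic acid.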